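Chloro on the core carbon next in the pyrazolyl series

The source may report more compounds than this note shows. Statements on the series, on what has been measured and on what is new or still open speak of the compounds shown alone.

Measured so far in a functional assay on CHO cells for agonist activity at Alpha-1D adrenergic receptor (Homo sapiens), read by FLIPR and calcium flux; on this read-out higher numbers stand for an effect only at larger amounts of compound and lower numbers for an effect already at smaller amounts:
compound 1 `c1cc(-c2cn[nH]c2)c2c(c1)C(c1ncc[nH]1)CC2`: 319 nM
compound 2 `c1ccc(-c2cccc3c2CCC3c2ncc[nH]2)nc1`: a limit, > 10000 nM

Within the data shown here, compound 1 holds the only number in this assay; the other value shown is a limit. Compound 2 reports a limit of the assay rather than a number. Among the measured compounds shown here, the one measured step, an at least 31-fold higher number from compound 1 to compound 2 (1.49 log units; beyond the scatter), swaps the aromatic group on the core, and its size rests on a value that sits at the limit of > 10000 nM in this assay, at which 1 of the 2 values shown sits.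

Compound 3 `Clc1ccc2c(c1-c1cn[nH]c1)CCC2c1ncc[nH]1` keeps the 1H-pyrazol-4-yl group of compound 1 and differs only by chloro in place of hydrogen on an aromatic carbon. For the measured compounds named here, no measured step touches this position or a chloro substituent; the step from compound 1 to compound 2 concerns a different group and does not bear on it. With no guidance, the change is expected to stay within the scatter, as a 1.1-fold lower number from compound 1 to compound 3 (0.03 log units; within the scatter).

Compound 3 is therefore estimated at 300 nM, between 90 nM and 1000 nM.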

Compound 3, half-maximal effective concentration: > 10000 nM
Compound 3 ended at the assay's limit (the forecaster's own chance of this, stated with the estimate: 10%); at least 33-fold (1.52 log units) between middle value and limit.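

In this assay the aromatic carbon ortho to a 1H-pyrazol-4-yl group proves sensitive to substitution: chloro in place of hydrogen there gives an at least 31-fold higher number from compound 1 to compound 3 (1.49 log units; beyond the scatter) with the 1H-pyrazol-4-yl group itself kept. Keeping that group is therefore not enough to hold the response seen with compound 1, and chloro, 1 heavy atom on the shared core, suffices to lose it, whereas the earlier step spoke only to the aromatic group itself. The step gives a bound and not a full size, as the value of compound 3 is a limit of the assay: the limit of > 10000 nM in this assay, at which 2 of the 3 values shown sit.

Whether the loss belongs to chloro or to any group on this carbon stays open, with fluoro, methyl and methoxy not among the compounds shown. Also open, as far as these compounds go, is whether chloro on the other aromatic carbons of the core gives the same result.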